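A Phenyl-to-Pyridinyl Swap on Compound 1

This account rests on a few compounds, and the source may have more. Where it says the series, first, only, none or still open, it means among the compounds named here.

Compound 1 `CS(=O)(=O)c1ccc(-c2cnc3[nH]cc(-c4nnc(-c5ccccc5)o4)c(=O)c3c2)cc1`: 8.6%
Compound 2 `N#Cc1ccc(-c2cnc3[nH]cc(-c4nnc(-c5ccc(Cl)cc5)o4)c(=O)c3c2)cc1`: 17.9%

Both numbers come from a functional assay on HCT-116 cells (Homo sapiens) for inhibition, read by MTT assay, with a stated time of 24 h, tested at 5 uM; a lower number here means less inhibition of growth, a higher number more inhibition of growth at the concentration tested. In this assay compound 1 gives 8.6%, the lowest of the two values, and compound 2 gives 17.9%, a number only within the scatter of compound 1, so the two cannot be ordered against each other. For the measured compounds named here, no pair of measured compounds differs in a single place, so no measured step is available.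

Compound 3 `CS(=O)(=O)c1ccc(-c2cnc3[nH]cc(-c4nnc(-c5cccnc5)o4)c(=O)c3c2)cc1` differs from compound 1 in one place: pyridin-3-yl in place of phenyl on an aromatic carbon. Going by the values given here, nothing among the measured compounds isolates this change, and the two values that exist lie close together at the low end of the scale. Compound 3 is therefore expected to give a number near compound 1, with a step of a number 1.4 percentage points higher from compound 1 to compound 3 (within the scatter) that is estimated not to go beyond the scatter in either direction. The estimate for compound 3 in this assay is 10%, with a range from 0% to 24%.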

Compound 3, percent growth inhibition at one concentration: 9.26%
Estimate against measurement, compound 3: 0.7 percentage points above, within the range that was stated.
By their numbers in this assay, from the lowest: compounds 1, 3 and 2 (each within the scatter of the next).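

In this assay, pyridin-3-yl in place of phenyl on this aromatic carbon of the five-membered ring gives a number 0.7 percentage points higher from compound 1 to compound 3 (within the scatter), the first step measured at this position. Exchanging the all-carbon ring for one with a ring nitrogen and a hydrogen-bond acceptor therefore does not separate the two compounds, and both stay at the low end of the scale at the single concentration tested. Nothing available explains why the two numbers lie together.

The compounds shown leave open whether any group on this carbon can move the number beyond the scatter, for example an amine, a carboxylic acid or a longer chain in place of the aromatic ring. For the compounds shown here, they also leave open whether a step at this position would be the same on a core carrying a different group from the one in compound 1.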